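The source may report more compounds than this note shows. Statements on the series, on what has been measured and on what is new or still open speak of the compounds shown alone.

Measured so far in an ADME assay on HeLa cells (Homo sapiens) for cytotoxicity; a higher number here means that more compound is tolerated, a lower number that less compound is tolerated:
compound 1 `CCN(CC)CN1C(=O)/C(=N/NC(=S)Nc2ccccc2)c2cc(Cl)ccc21` gives 13500 nM
compound 2 `CCN(CC)CN1C(=O)/C(=N/NC(=S)Nc2ccc(Cl)cc2)c2ccccc21` gives 9800 nM
compound 3 `CCN(CC)CN1C(=O)/C(=N/NC(=S)Nc2ccccc2)c2ccccc21` gives 10800 nM

Compound 2 does not stand apart on these numbers: its value and those of compound 3 and compound 1 all lie within the usual scatter of one another, so no order among the three can be read from them. The unmeasured compound 4 `CCN(CC)CN1C(=O)/C(=N/NC(=S)Nc2ccc(C)cc2)c2ccccc21` differs from compound 2 in one place: methyl in place of chloro on an aromatic carbon. Within the data shown here, two measured steps bear on this. Removing the chloro from the same place gave a 1.1-fold higher number from compound 2 to compound 3 (0.04 log units; within the scatter). Removing a chloro from a different aromatic carbon of the shared core gave a 1.3-fold lower number from compound 1 to compound 3 (0.10 log units; within the scatter). Neither step swapped chloro for methyl, so the exact change has not been tested here, but both show that a chloro at either place moves the tolerated concentration by no more than the scatter. A methyl in its place is therefore expected to leave the number in this assay about where compound 2 sits, with no step beyond the scatter in either direction. The estimate for compound 4 is 10500 nM, with a range from 5000 nM to 22000 nM. That corresponds to an expected step of a 1.1-fold higher number from compound 2 to compound 4 (0.03 log units; within the scatter).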

Compound 4, half-maximal cytotoxic concentration: 10700 nM
Compound 4: middle estimate off by 1.0-fold (0.01 log units), on the low side, and the stated range covers the measured number.
By their numbers in this assay, from the lowest: compounds 2, 4, 3 and 1 (each within the scatter of the next).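

In this assay, among these compounds, turning the 4-chlorophenyl group into 4-methylphenyl gives a 1.1-fold higher number from compound 2 to compound 4 (0.04 log units; within the scatter) and so tests, for the first time, a replacement at this place rather than only the removal of a chloro. Methyl in place of hydrogen at the same carbon gives a 1.0-fold lower number from compound 3 to compound 4 (0.00 log units; within the scatter), so this place, on the ring of carbon only and para to a large group, has now carried hydrogen, chloro and methyl, and the three compounds lie within the scatter of one another, which means these three groups cannot be told apart in this assay. No measurement is available that would explain this lack of a difference.

These three compounds leave open whether a group of another kind at this place, such as an amine, a carboxylic acid or a longer chain like butyl, would also stay within the scatter. Going by these compounds, it also remains open whether methyl would behave the same way at the other aromatic carbon, on the shared core, where compound 1 carries its chloro.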